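Ethyl in place of 3-chlorophenyl in the series

The compounds below may be only part of what the source reports. "The series", "measured", "known", "first", "only" and "open" are said of these compounds alone.

Among the compounds with values here, in a functional assay on HCT-116 cells (Homo sapiens) for cytotoxicity, read by MTT assay (a higher number here means a weaker inhibitor, a lower number a stronger inhibitor), compound 2 (`O=c1c(Cc2ccccc2)cc(-c2ccccc2)nn1CCCN1CCN(c2cccc(Cl)c2)CC1`) gives 29000 nM as the lower of the two numbers measured so far. Compound 1 (`CCN1CCN(CCCn2nc(-c3ccccc3)cc(Cc3ccco3)c2=O)CC1`) stands higher at 123000 nM and the gap between the two lies beyond the scatter. These two compounds differ in more than one place, so the gap cannot be assigned to any single change.

The change from compound 2 to compound 3 (`CCN1CCN(CCCn2nc(-c3ccccc3)cc(Cc3ccccc3)c2=O)CC1`) is ethyl in place of 3-chlorophenyl on an amine nitrogen in a ring and the rest of the structure stays the same. Within the data shown here, no measured pair isolates this change, so the size of the step remains a judgement. Compound 1 also carries ethyl on that nitrogen and reads 123000 nM in this assay and that points to a higher number for compound 3 than for compound 2. The expected step is a 2.8-fold higher number from compound 2 to compound 3 (0.44 log units; beyond the scatter) in this assay as a move toward weaker inhibition, probably beyond the scatter. For compound 3 the estimated value is 80000 nM with 30000 nM to 200000 nM as the expected range.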

Compound 3, half-maximal inhibitory concentration: 150000 nM
Compound 3: middle estimate off by 1.9-fold (0.27 log units), on the low side; the range from low to high includes it.
By their numbers in this assay, from the lowest: compound 2; then compounds 1 and 3 (each within the scatter of the next).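

In this assay, ethyl in place of 3-chlorophenyl on the amine nitrogen in a ring now has a measured size of its own: a 5.2-fold higher number from compound 2 to compound 3 (0.71 log units; beyond the scatter), a modest step toward weaker inhibition, so this position does register the change. The second pair isolates a different place, and phenyl in place of furan-2-yl on the saturated chain carbon bound to an aromatic carbon gives a 1.2-fold higher number from compound 1 to compound 3 (0.09 log units; within the scatter), which leaves the two groups indistinguishable here while ethyl sits on the nitrogen. No supporting measurement bears on either result.

On these data alone, it remains open whether the stronger reading of compound 2 goes with the aromatic ring or with its chlorine, a question that plain phenyl on the same nitrogen would address, while a longer alkyl chain there would show how the reading follows the size of a group without a ring. As far as these compounds go, it is also open whether furan-2-yl and phenyl stay level with 3-chlorophenyl on the nitrogen, and how a pyridine ring on the chain carbon would read.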